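Coumarin thiophenes at the assay limit: a bromothiophene variant

The source may hold more compounds than are shown below. What is called first, only, known or untested is meant among the compounds shown, and "the series" means these compounds.

Compound 1 `CC(=O)Oc1cccc2cc(-c3cccs3)c(=O)oc12` gives > 30000 nM in a functional assay on isolated protein for antagonist activity at adenosine receptor A2b (Homo sapiens) (a lower number here means a stronger inhibitor, a higher number a weaker inhibitor), a limit of the assay.
Compound 2 `CC(=O)Oc1cccc2cc(-c3ccsc3)c(=O)oc12` gives > 30000 nM in this assay, a limit.
Compound 3 `CC(=O)Oc1ccc2cc(-c3ccsc3)c(=O)oc2c1OC(C)=O` gives > 30000 nM in this assay, again a limit.

Compound 3 therefore stands where the other two stand: at a limit, with no number of its own. All values shown sit there, as the limit of > 30000 nM in this assay, at which 3 of the 3 values shown sit, records. The step that the two limits leave unreadable from compound 1 to compound 2 and the step that the two limits leave unreadable from compound 2 to compound 3 are both unreadable, since both ends are limits, so neither the change to thiophen-3-yl nor the added acetoxy group left a measurable trace.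

Compound 4 `CC(=O)Oc1ccc2cc(-c3cc(Br)cs3)c(=O)oc2c1OC(C)=O` differs from compound 3 by one change: 4-bromothiophen-2-yl in place of thiophen-3-yl on an aromatic carbon. No measured step bears on it in a readable way; the only related step, the change of thiophen-2-yl to thiophen-3-yl in a step that the two limits leave unreadable from compound 1 to compound 2, gave no sign of movement, and the shared core has not produced a number in any compound shown. The expectation for compound 4 is therefore a step of a number no higher from compound 3 to compound 4 (the limit leaves the size open) in this assay, which means no change beyond the scatter. Compound 4 is estimated at 30000 nM in this assay, expected between 6000 nM and 150000 nM, most likely reported again as a limit.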

Compound 4, inhibition constant: > 30000 nM
Compound 4: no number, only a limit; the forecaster's own chance of this, stated with the estimate: 75%; the middle value lies on the limit itself.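

Compound 4 gives > 30000 nM in this assay, a limit and not a number. The change from compound 3 to compound 4 therefore cannot be read, as both ends are limits: the limit of > 30000 nM in this assay, at which 4 of the 4 values shown sit.

The compounds shown leave open how strongly any of them acts at this receptor, and whether any change on the shared core can move the read-out.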